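The source may report more compounds than this note shows. Statements on the series, on what has been measured and on what is new or still open speak of the compounds shown alone.

Of the compounds shown here, three sharing one core have been measured in a physicochemical assay for solubility, at pH 6; a higher number here means a more soluble compound, a lower number a less soluble compound. Compound 1 `N#Cc1ccc(-c2cc(-c3ccc(C(N)=O)cc3)cc(-c3ccco3)n2)cc1` carries a carbamoyl group and gives 10000 nM. Compound 2 `N#Cc1ccc(-c2cc(-c3ccccc3)cc(-c3ccco3)n2)cc1` has only hydrogen at that spot and gives 2000 nM. Compound 3 `N#Cc1ccc(-c2cc(-c3ccc(-c4nnn[nH]4)cc3)cc(-c3ccco3)n2)cc1` carries a 1H-tetrazol-5-yl group and gives 18000 nM; this is the highest of the three numbers, although its gap to compound 1 is within the scatter, so the two cannot be ranked against each other.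

Compound 4 `CNC(=O)c1ccc(-c2cc(-c3ccc(C#N)cc3)nc(-c3ccco3)c2)cc1` is the next step from compound 3: methylcarbamoyl in place of 1H-tetrazol-5-yl on an aromatic carbon. The change thus swaps one small hydrogen-bond-donating group for another at the same place on the ring.

The measured steps that bear on this are a 1.8-fold higher number from compound 1 to compound 3 (0.26 log units; within the scatter), a 9.0-fold higher number from compound 2 to compound 3 (0.95 log units; beyond the scatter) and a 5.0-fold lower number from compound 1 to compound 2 (0.70 log units; beyond the scatter). Removing the group entirely lowers the number clearly, while swapping carbamoyl for the tetrazole barely moves it. Methylcarbamoyl is closer to carbamoyl than to hydrogen, so the expected step in this assay is a 2.0-fold lower number from compound 3 to compound 4 (0.30 log units; within the scatter), small and probably within the scatter.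

Compound 4 is therefore estimated at 9000 nM, with a likely range from 4000 nM to 20000 nM.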

Compound 4, solubility: 25000 nM
For compound 4 the middle estimate is 2.8-fold (0.44 log units) below the measured one; the measured number lies above the stated range.
By their numbers in this assay, from the lowest: compound 2; then compounds 1, 3 and 4 (each within the scatter of the next, the first and the last beyond it).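

In this assay, methylcarbamoyl in place of hydrogen on the aromatic carbon gives a 13-fold higher number from compound 2 to compound 4 (1.10 log units; beyond the scatter) and so becomes the third group at this position, after carbamoyl and 1H-tetrazol-5-yl, to stand clear of bare hydrogen. Methylcarbamoyl in place of 1H-tetrazol-5-yl gives a 1.4-fold higher number from compound 3 to compound 4 (0.14 log units; within the scatter) and so cannot be told apart from it here, even though a group with a five-membered aromatic ring leaves and a group with no ring enters. The sharpest new reading comes from the smallest edit, since methyl in place of hydrogen on the amide-type nitrogen gives a 2.5-fold higher number from compound 1 to compound 4 (0.40 log units; beyond the scatter) and shows that this position can respond to a single added carbon on the amide.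

Nothing shown here accounts for these steps. Still open, on these data alone, is whether the methyl step continues with a longer chain such as ethyl on the amide nitrogen, and how a carboxylic acid or an amine at the same place would compare with methylcarbamoyl and 1H-tetrazol-5-yl.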